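Sulfonyl series: replacing 2,5-dimethylphenyl with 3-hydroxy-4-methoxyphenyl

The source may hold more compounds than are shown below. What is called first, only, known or untested is meant among the compounds shown, and "the series" means these compounds.

Measured in a functional assay on DU-145 cells (Homo sapiens) for inhibition, read by trypan blue exclusion, with a stated time of 96 h; a lower number here means a stronger inhibitor of growth, a higher number a weaker inhibitor of growth:
- compound 1 `CN(C)c1ccc(/C=C(/SCc2ccccc2Cl)C(=O)c2ccc(Cl)cc2)cc1` gives > 100000 nM
- compound 2 `Cc1ccc(C)c(/C=C(\C(=O)c2ccc(Cl)cc2)S(=O)(=O)c2ccc(Br)cc2)c1` gives 1000 nM

The entry for compound 1 at > 100000 nM is a limit of the assay and not a number. Within the data shown here, compound 2 at 1000 nM holds the only actual number so far, with no second number to rank it against.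

Compound 3 `COc1ccc(/C=C(\C(=O)c2ccc(Cl)cc2)S(=O)(=O)c2ccc(Br)cc2)cc1O` is not yet measured. It carries 3-hydroxy-4-methoxyphenyl in place of 2,5-dimethylphenyl on a double-bonded chain carbon bound to a double-bonded chain carbon and is otherwise unchanged.

Among the measured compounds shown here, no measured step exists to scale this change, and the expectation rests on the structures alone. Expected is a 5.0-fold lower number from compound 2 to compound 3 (0.70 log units; beyond the scatter) toward stronger inhibition of growth, with wide uncertainty.

Compound 3 is estimated at 200 nM with an expected range from 20 nM to 1500 nM in this assay for now.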

Compound 3, concentration for 50% growth inhibition: 10000 nM
The estimate for compound 3 lay 50-fold (1.70 log units) below the measured number, and the stated range ends below it.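

In this assay, the sulfonyl series now has a measured step at the aryl group on a double-bonded chain carbon bound to a double-bonded chain carbon, with a 10-fold higher number from compound 2 to compound 3 (1.00 log units; beyond the scatter) on replacing 2,5-dimethylphenyl by 3-hydroxy-4-methoxyphenyl. This position therefore responds to the choice of aryl group, and of the two groups seen there, 2,5-dimethylphenyl gives the stronger inhibition of growth. Compound 3 still gives an actual number, whereas compound 1 alone stands at a limit of the assay: the limit of > 100000 nM in this assay, at which 1 of the 3 values shown sits.

This single step changes the hydroxy and methoxy groups together, so it cannot show what either contributes alone. Going by these compounds, how the position would respond to an aryl ring carrying a carboxylic acid remains open, as does whether the same step holds with other groups on the sulfonyl side.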